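The source may hold more compounds than are shown below. What is called first, only, known or untested is meant among the compounds shown, and "the series" means these compounds.

Values in a functional assay on CEM-DNR-bulk cells (Homo sapiens), read by MTT assay, with a stated time of 72 h (on this read-out higher numbers stand for weaker inhibition and lower numbers for stronger inhibition), so far
- Compound 1 `CNc1ncnc2c1c(-c1cccs1)cn2[C@@H]1O[C@H](CO)[C@@H](O)[C@H]1O` gives > 20000 nM (a limit)
- Compound 2 `O=c1[nH]cnc2c1c(-c1ccccc1)cn2[C@@H]1O[C@H](CO)[C@@H](O)[C@H]1O` gives > 20000 nM (a limit)
- Compound 3 `Cc1nc(N)c2c(-c3ccoc3)cn([C@@H]3O[C@H](CO)[C@@H](O)[C@H]3O)c2n1` gives > 20000 nM (a limit)

In this assay compound 3 gives > 20000 nM as a limit, not a number. It therefore has no exact position on the scale, and the same is true of compound 1 and compound 2. Together they make up the limit of > 20000 nM in this assay, at which 3 of the 3 values shown sit, as the whole of the evidence so far.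

Compound 4 `Cc1nc(N)c2c(-c3cc4ccccc4o3)cn([C@@H]3O[C@H](CO)[C@@H](O)[C@H]3O)c2n1` carries 1-benzofuran-2-yl in place of furan-3-yl on an aromatic carbon of the shared core (1-benzofuran-2-yl in place of furan-3-yl on an aromatic carbon). Among the measured compounds shown here, no step between measured compounds is available as a guide. Compound 1, compound 2 and compound 3 differ in their groups yet all share the limit of > 20000 nM in this assay, at which 3 of the 3 values shown sit, as their place, so the step expected in this assay is none beyond the scatter. Any shift that does appear is expected toward stronger inhibition, since only that direction could show up as a number. The expected step is an at least 1.3-fold lower number from compound 3 to compound 4 (0.12 log units; that floor lies within the scatter) and remains an estimate. Compound 4 is estimated at 15000 nM within an expected range of 4000 nM to 20000 nM and may well read as a limit again.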

Compound 4, half-maximal inhibitory concentration: 6310 nM
The estimate for compound 4 lay 2.4-fold (0.38 log units) above the measured number, within the range that was stated.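

In this assay, the group on this aromatic carbon can move the read-out: 1-benzofuran-2-yl in place of furan-3-yl gives an at least 3.1-fold lower number from compound 3 to compound 4 (0.50 log units; beyond the scatter). The change adds a six-membered aromatic ring of carbon only, while the counts of hydrogen-bond donors and acceptors stay the same, so the added ring is the main structural difference, though these data do not show that it causes the gain. Among the compounds shown here, compound 4 is also the only compound here that reads as a number rather than a limit, which gives this set its first exact point on the scale: the limit of > 20000 nM in this assay, at which 3 of the 4 values shown sit.

As far as these compounds go, it remains open whether the added ring or the different attachment point on the furan matters more, a question that a furan-2-yl group could help settle. From the compounds shown here alone, it is also open how an amine or a carboxylic acid on the added ring would read.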